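Removing the ring chloro from compound 1

This account rests on a few compounds, and the source may have more. Where it says the series, first, only, none or still open, it means among the compounds named here.

Measured compounds:
compound 1 `CCCc1nc(-c2ccccc2)c(CNCCN2CCN(c3ccccc3Cl)CC2)o1`, 4370 nM
compound 2 `CCCc1nc(-c2ccccc2)c(CNCCCN2CCN(c3ccc(F)cc3)CC2)o1`, 3210 nM
compound 3 `CCCc1nc(-c2ccccc2)c(CNCCCN2CCN(c3ccccc3Cl)CC2)o1`, 2800 nM

In an assay on HEK293 cells for inhibition of Voltage-dependent T-type calcium channel subunit alpha-1G (Homo sapiens), read by patch clamp (a higher number here means a weaker inhibitor, a lower number a stronger inhibitor), compound 1 gives 4370 nM. Its number sits with those of the other two compounds, and the gaps to compound 2 at 3210 nM and to compound 3 at 2800 nM are both within the scatter, so no order among the three can be claimed.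

Compound 4 `CCCc1nc(-c2ccccc2)c(CNCCN2CCN(c3ccccc3)CC2)o1` differs from compound 1 in one place: hydrogen in place of chloro on an aromatic carbon. Cut one bond further out, the change reads 2-chlorophenyl to phenyl.

Among the compounds with values here, only one measured step touches that aryl ring, the step of a 1.1-fold lower number from compound 2 to compound 3 (0.06 log units; within the scatter), where 2-chlorophenyl replaced 4-fluorophenyl on the amine nitrogen in the ring. Within the data shown here, that step was within the scatter, and it is not the same change as the one from compound 1 to compound 4, so it bears on it only loosely. Among the measured compounds shown here, there is no measured pair in which the chloro alone is removed.

Given that, the expected step of a 1.0-fold higher number from compound 1 to compound 4 (0.01 log units; within the scatter) in this assay is small, with no direction beyond the scatter. Compound 4 is therefore estimated at 4500 nM, with a range from 2000 nM to 10000 nM.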

Compound 4, half-maximal inhibitory concentration: 10300 nM
Estimate against measurement, compound 4: 2.3-fold (0.36 log units) below; the measured number lies above the stated range.
By their numbers in this assay, from the lowest: compounds 3, 2 and 1 (each within the scatter of the next); then compound 4.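

The chloro on this aromatic carbon counts in this assay: with hydrogen in its place, the number goes up (a 2.4-fold higher number from compound 1 to compound 4 (0.37 log units; beyond the scatter)), so on this chain the plain phenyl is the weaker inhibitor of the pair. The earlier step on this aryl ring (a 1.1-fold lower number from compound 2 to compound 3 (0.06 log units; within the scatter)) swapped one substituted ring for another and stayed within the scatter, so it could not show this. Compound 1 and compound 4 are the first pair to isolate the change from 2-chlorophenyl to phenyl, and nothing shown accounts for the rise.

On these data alone, it remains open whether hydrogen in place of chloro would shift the number in the same way on the longer chain of compound 3, since this one pair speaks only for the chain of compound 1. As far as these compounds go, it also remains open whether chloro itself is needed on this aromatic carbon, or whether another group there, such as a methyl or a methoxy, would keep the number near that of compound 1.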